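The source may hold more compounds than are shown below. What is called first, only, known or untested is meant among the compounds shown, and "the series" means these compounds.

In a functional assay on MCF7 cells (Homo sapiens) for antiproliferative activity, read by sulforhodamine B assay, with a stated time of 72 h (on this read-out lower numbers stand for stronger inhibition and higher numbers for weaker inhibition), compound 1 `O=C(Cn1nc(Cc2ccccc2)c2ccccc2c1=O)Nc1ccccc1Cl` gives 89000 nM and compound 2 `O=C(Cn1nc(Cc2ccccc2)c2ccccc2c1=O)Nc1ccc(Cl)cc1` gives 13000 nM, the lower of the two numbers. Compound 3 `O=C(Cn1nc(Cc2ccccc2)c2ccccc2c1=O)Nc1cccc(C(F)(F)F)c1` differs from compound 2 on an amide-type nitrogen: 3-(trifluoromethyl)phenyl in place of 4-chlorophenyl on an amide-type nitrogen. For the measured compounds named here, the only measured step that bears on this is a 6.8-fold lower number from compound 1 to compound 2 (0.84 log units; beyond the scatter), a modest change between two chlorophenyl groups. Going by the values given here, no measured compound carries the 3-(trifluoromethyl)phenyl group, so a step of similar or smaller size is expected, leaning towards a higher number than compound 2 shows at 13000 nM. The expected change is a 1.7-fold higher number from compound 2 to compound 3 (0.23 log units; within the scatter). For compound 3, the estimated value is 22000 nM, within an expected range of 6000 nM to 80000 nM.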

Compound 3, half-maximal inhibitory concentration: 3850 nM
Estimate against measurement, compound 3: 5.7-fold (0.76 log units) above, outside the stated range (below it).
By their numbers in this assay, from the lowest: compound 3; then compound 2; then compound 1.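

Compound 3 shows that the amide-type nitrogen can carry a group other than chlorophenyl and still improve on both chlorophenyl compounds in this assay: the 3-(trifluoromethyl)phenyl group gives a 3.4-fold lower number from compound 2 to compound 3 (0.53 log units; beyond the scatter) and a 23-fold lower number from compound 1 to compound 3 (1.36 log units; beyond the scatter). The larger group, with 10 heavy atoms against 7, is therefore accepted at this position, and compound 3 has the lowest number of the three. No measurement shown here accounts for this gain. Going by these compounds, whether it comes from the trifluoromethyl group itself or from where that group sits on the phenyl remains open. So does the effect of an unsubstituted phenyl, an amine or a carboxylic acid at this position.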